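The source may report more compounds than this note shows. Statements on the series, on what has been measured and on what is new or still open speak of the compounds shown alone.

Measured so far:
- compound 1, `Cc1cccc(NC(=O)N[C@@H](C)c2ccccc2)c1`: 100%
- compound 2, `CC(C)c1cccc(NC(=O)N[C@H](C)c2ccccc2)c1`: 61%

In an ADME assay on the whole organism with Oryza sativa as the target, tested at 1 uM (on this read-out higher numbers stand for a weaker effect at the one concentration tested and lower numbers for a stronger effect), compound 1 gives 100%, while compound 2 gives 61%, the lowest of the two numbers and a gap to compound 1 that lies beyond the scatter. Going by the values given here, no single-change step between measured compounds is available, so the two values are taken only as they stand.

Compound 3, `CC(C)c1cccc(NC(=O)N[C@@H](C)c2ccccc2)c1`, is not yet measured. It differs from compound 2 as follows: the two compounds have the same atoms and bonds and differ only in configuration as drawn: 1 of 1 stereo elements differ; a stereocentre at a saturated chain carbon is drawn R in compound 2 and S in compound 3. Among the compounds with values here, no pair isolates this kind of change, so its effect is unknown from the data. Compound 1, which is drawn with the same configuration as compound 3 but carries a smaller group, sits at the top of the scale in this assay; this is a weak hint that the configuration of compound 3 may read higher, but it is not a clean comparison.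

The step from compound 2 is therefore expected to be upward, toward a weaker effect, of a size that may or may not exceed the scatter: a number 19 percentage points higher from compound 2 to compound 3 (beyond the scatter). Compound 3 is estimated at 80% in this assay, with a range of 45% to 100%.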

Compound 3, a percentage reported as activity, at one concentration (the size of the read-out at that concentration, not a potency): 84%
Beside the measured number, compound 3's estimate is 4 percentage points below it, and the stated range covers the measured number.
By their numbers in this assay, from the lowest: compound 2; then compound 3; then compound 1.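

The pair gives the series its first clean read of the stereocentre at the saturated chain carbon: in this assay, the R to S change comes with a number 23 percentage points higher from compound 2 to compound 3 (beyond the scatter), and this step can be tied to that stereocentre alone: the fact that compounds 2 and 3 differ only in the configuration as drawn

With the S configuration held, the second clean comparison covers isopropyl in place of methyl on an aromatic carbon, and it gives a number 16 percentage points lower from compound 1 to compound 3 (beyond the scatter), so the substituent also moves the read-out, here toward a stronger effect at the one concentration tested. Each of the two single changes therefore shifts the number beyond the scatter, and the lowest value in the series belongs to compound 2, which combines isopropyl with the R configuration.

The compounds shown leave open whether the R configuration would also lower the number with methyl on the aromatic carbon, since the configuration step is known only with isopropyl in place. They also leave open how the read-out responds to other groups on that aromatic carbon, such as a methoxy group, a chlorine atom or a tert-butyl group.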